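This account rests on a few compounds, and the source may have more. Where it says the series, first, only, none or still open, it means among the compounds named here.

Compound 1 `COc1ncc(-c2ccc3ncnc(Nc4ccc(OCCO)c(F)c4)c3c2)cc1NS(=O)(=O)c1ccc(F)cc1F` in a functional assay on HCT-116 cells (Homo sapiens) for antiproliferative activity, read by sulforhodamine B assay, with a stated time of 72 h; a lower number here means a stronger inhibitor, a higher number a weaker inhibitor: 9160 nM
Compound 2 `COc1ncc(-c2ccc3ncnc(Nc4cnn(CC(=O)O)c4)c3c2)cc1NS(=O)(=O)c1ccc(F)cc1F` in this assay: 1540 nM
Compound 3 `COc1cc(Nc2ncnc3ccc(-c4cnc(OC)c(NS(=O)(=O)c5ccc(F)cc5F)c4)cc23)ccc1OCCO` in this assay: 5720 nM

Compound 3 stands second highest of the three numbers. Its nearest neighbour is compound 1, where compound 3 differs only by a 1.6-fold lower number from compound 1 to compound 3 (0.20 log units; within the scatter); its furthest is compound 2, where a 3.7-fold higher number from compound 2 to compound 3 (0.57 log units; beyond the scatter) separates them. Compound 4 `COc1ncc(-c2ccc3ncnc(Nc4ccc(OCCO)nc4)c3c2)cc1NS(=O)(=O)c1ccc(F)cc1F` is the next member and is yet to be measured in this assay. It differs from compound 3 in one place: 6-(2-hydroxyethoxy)pyridin-3-yl in place of 4-(2-hydroxyethoxy)-3-methoxyphenyl on a nitrogen on an aromatic ring.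

For the measured compounds named here, two measured steps bear on this change. Swapping one group on the same nitrogen for another has given a 5.9-fold lower number from compound 1 to compound 2 (0.77 log units; beyond the scatter) and a 3.7-fold higher number from compound 2 to compound 3 (0.57 log units; beyond the scatter), both modest, while a small change on that group gave a 1.6-fold lower number from compound 1 to compound 3 (0.20 log units; within the scatter), within the scatter. The group entering in compound 4 keeps the 2-hydroxyethoxy chain of compound 3 and replaces the ring it sits on, so the step is expected to be small, perhaps a slightly lower number, and is estimated as a 1.2-fold lower number from compound 3 to compound 4 (0.08 log units; within the scatter). Compound 4 is therefore expected to give 4800 nM, with a range of 1900 nM to 12000 nM.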

Compound 4, half-maximal inhibitory concentration: 2340 nM
Compound 4: middle estimate off by 2.1-fold (0.31 log units), on the high side; low and high end bracket the measured number.
By their numbers in this assay, from the lowest: compounds 2 and 4 (each within the scatter of the next); then compounds 3 and 1 (each within the scatter of the next).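

In this assay, a 2.4-fold lower number from compound 3 to compound 4 (0.39 log units; beyond the scatter) shows that, with the 2-hydroxyethoxy chain kept, exchanging the ring that carries it on this nitrogen can move the number beyond the scatter. The same group gives a 3.9-fold lower number from compound 1 to compound 4 (0.59 log units; beyond the scatter) when it replaces 3-fluoro-4-(2-hydroxyethoxy)phenyl, while a 1.5-fold higher number from compound 2 to compound 4 (0.18 log units; within the scatter) places it within the scatter of the 1-(carboxymethyl)-1H-pyrazol-4-yl group, so this position does not need a carboxymethyl group to reach that range. No measurement given here accounts for these differences.

The compounds shown do not separate the effect of the ring nitrogen from that of losing the fluoro or methoxy group. On these data alone, it also remains open how the number would respond on the pyridin-3-yl ring to a longer chain or to an amine in place of the terminal hydroxyl.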